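From acetoxy to benzoyloxy on the shared core

A few compounds are considered here, and "the series" means these few. Any claim that something is new, unique, unknown or untested is made for them only; others in the source may bear on it.

Values measured in a functional assay on MCF7 cells (Homo sapiens) for antiproliferative activity, read by MTT assay, with a stated time of 48 h; on this read-out lower numbers stand for stronger inhibition and higher numbers for weaker inhibition
- Compound 1 `CC(C)=CCC[C@]1(C)/C=C/[C@@H](OC(=O)C=C(C)C)[C@](C)(O)/C=C/C(=O)/C(C=O)=C\C1` gives 12600 nM
- Compound 2 `CC(C)=CCC[C@]1(C)/C=C/[C@@H](OC(=O)C=C(C)C)[C@](C)(O)/C=C/C(=O)/C(CN2CCN(C)CC2)=C\C1` gives 550 nM
- Compound 3 `CC(=O)O[C@@H]1/C=C/[C@@](C)(CCC=C(C)C)C/C=C(/CO)C(=O)/C=C/[C@@]1(C)O` gives 7890 nM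

Compound 3 lies within the scatter of compound 1, and both lie well above compound 2. Compound 4 `CC(C)=CCC[C@]1(C)/C=C/[C@@H](OC(=O)c2ccccc2)[C@](C)(O)/C=C/C(=O)/C(CO)=C\C1` has not yet been measured. It differs from compound 3 by one exchange (phenyl in place of methyl on a carbonyl carbon), phenyl in place of methyl on a carbonyl carbon, which turns acetoxy into benzoyloxy.

Among the measured compounds shown here, the one measured step (a 23-fold lower number from compound 1 to compound 2 (1.36 log units; beyond the scatter)) is large, but it puts (4-methylpiperazin-1-yl)methyl in place of formyl and leaves the ester untouched, so it does not bear on this exchange. For the measured compounds named here, no measured pair isolates a change of the ester group. Without such evidence, no shift beyond the scatter in this assay is expected, and the estimate stays close to compound 3 at 7890 nM with a wide range. The expected step (a 1.3-fold lower number from compound 3 to compound 4 (0.12 log units; within the scatter)) is small. The estimate for compound 4 is 6000 nM (2000 nM to 16000 nM).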

Compound 4, half-maximal inhibitory concentration: 27000 nM
Compound 4: middle estimate off by 4.5-fold (0.65 log units), on the low side, outside the stated range (above it).
By their numbers in this assay, from the lowest: compound 2; then compounds 3 and 1 (each within the scatter of the next); then compound 4.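

The ester at this position is not neutral in this assay: phenyl in place of methyl on the carbonyl carbon gives a 3.4-fold higher number from compound 3 to compound 4 (0.53 log units; beyond the scatter). Among the compounds shown here, no earlier pair changed the ester, so this is the first sign that the group on this carbonyl carbon can move the read-out, and here acetoxy gives the lower number and benzoyloxy the higher. Nothing available accounts for this shift.

Going by these compounds, it remains open whether the aromatic ring itself goes with the higher number, or whether a longer chain such as butanoyl, or an acyl group carrying an amine, would shift it as well. One step also cannot tell whether the same exchange would act alike on a core carrying (4-methylpiperazin-1-yl)methyl, as compound 2 does.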